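The compounds below may be only part of what the source reports. "The series", "measured", "known", "first", "only" and "open" are said of these compounds alone.

This account follows a change made to compound 1 `C/C(=N\OCc1ccncc1)c1ccc(Sc2cc(F)cc(C3CCOCC3)c2)cc1` and what it may mean for compound 4 `C/C(=N\OC(=O)N(C)C)c1ccc(Sc2cc(F)cc(C3CCOCC3)c2)cc1`, which has not yet been measured. In a functional assay (blood) for inhibition, with Homo sapiens as the target (a higher number here means a weaker inhibitor, a lower number a stronger inhibitor), compound 1 gives 300 nM, the higher of the two numbers obtained so far. Its nearest measured neighbour is compound 2 `C/C(=N/O)c1ccc(COc2cc(F)cc(C3CCOCC3)c2)cc1`, which in this assay gives 40 nM; the gap between these two values lies beyond the usual scatter. Compound 3 `C/C(=N\O)c1ccccc1Sc1cc(F)cc(C2CCOCC2)c1` gives in this assay only a limit, > 10000 nM, and not a number. Of the three values shown, one sits at the limit of > 10000 nM in this assay, at which 1 of the 3 values shown sits.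

The step from compound 1 to compound 4 is a single change: dimethylcarbamoyl in place of (pyridin-4-yl)methyl on an oxygen. It takes place on an oxygen whose other neighbour is a double-bonded nitrogen. Within the data shown here, no measured pair in this set makes a comparable change, so the size of the step in this assay cannot be read from the data at hand; it is expected to be modest, more likely a small loss than a gain. Compound 4 is therefore expected to give about 450 nM in this assay, within a range from 120 nM to 2000 nM. The step that this estimate means, a 1.5-fold higher number from compound 1 to compound 4 (0.18 log units; within the scatter), is expected to stay close to the scatter of the measurement.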

Compound 4, half-maximal inhibitory concentration: 2610 nM
Compound 4: the middle estimate sits 5.8-fold (0.76 log units) below what was measured; measured number outside the range, above it.
By their numbers in this assay, from the lowest: compound 2; then compound 1; then compound 4. At a limit, above all of these: compound 3.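

In this assay, the oxygen whose other neighbour is a double-bonded nitrogen proves sensitive to the group it carries: dimethylcarbamoyl in place of (pyridin-4-yl)methyl gives an 8.7-fold higher number from compound 1 to compound 4 (0.94 log units; beyond the scatter). Among these compounds, this is the only step in the set that can be read at this place, and it shows that with the rest of compound 1 unchanged, this one exchange moves the number beyond the scatter. Nothing in the data explains the size of this step or shows which feature of the two groups accounts for it.

A single step at this oxygen cannot show whether the change in the number follows from losing the (pyridin-4-yl)methyl group or from bringing in dimethylcarbamoyl, and a benzyl group or a plain methyl on the same oxygen would help to separate the two. Also open, as far as these compounds go, is how a different carbamoyl, such as one with a morpholine in place of the dimethylamino part, would compare with compound 4 on the same core.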